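Swapping (Methylsulfonyl)oxy for (4-Aminocyclohexyl)amino on One Core

The compounds below may be only part of what the source reports. "The series", "measured", "known", "first", "only" and "open" are said of these compounds alone.

Compound 1 `CS(=O)(=O)Oc1c(C(=O)NCc2ccc(F)cc2)nc(Br)c2cccnc12` was tested in a functional assay on HCT-116 cells (Homo sapiens) for cytotoxicity, read by MTT assay, with a stated time of 72 h; a lower number here means a stronger inhibitor, a higher number a weaker inhibitor. In this assay compound 1 gives > 20000 nM, which is a limit of the assay rather than a measured number. Compound 1 therefore stands at the limit of > 20000 nM in this assay, at which 1 of the 2 values shown sits, so all that is known is that it is a weak inhibitor at best. A second compound of the same series, compound 2 `C[C@H](CO)Nc1nc(C(=O)NCc2ccc(F)cc2)c(O)c2ncccc12`, was also entered; in this assay compound 2 gives "not determined" (no result reported), so it offers no number to compare against.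

Compound 3 `N[C@H]1CC[C@H](Nc2c(C(=O)NCc3ccc(F)cc3)nc(Br)c3cccnc23)CC1` has not yet been measured. It differs from compound 1 in one place: (4-aminocyclohexyl)amino in place of (methylsulfonyl)oxy on an aromatic carbon. For the measured compounds named here, no measured step covers this kind of exchange, so any expectation rests on compound 1 alone, whose result is only a limit. A gain in potency is expected, with an at least 8.0-fold lower number from compound 1 to compound 3 (0.90 log units; beyond the scatter) as the estimated step, taken from a starting point that is not itself a firm number. Compound 3 is expected to give about 2500 nM in this assay, with a range from 300 nM to 20000 nM, and a real chance that only a limit is again reported.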

Compound 3, half-maximal inhibitory concentration: 7000 nM
Compound 3: the middle estimate sits 2.8-fold (0.45 log units) below what was measured; the measured number falls inside the stated range.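

For the compounds shown here, this exchange gives the first firm number for a change at this aromatic carbon, para to a bromo group on the shared core. In this assay, putting (4-aminocyclohexyl)amino in place of (methylsulfonyl)oxy brings an at least 2.8-fold lower number from compound 1 to compound 3 (0.45 log units; beyond the scatter), so what sits at this position clearly affects the read-out, and a group holding a six-membered non-aromatic ring and two defined stereocentres is compatible with measurable cytotoxicity. Compound 1 gives only a limit, so this step marks the smallest possible change and not its true size: the limit of > 20000 nM in this assay, at which 1 of the 3 values shown sits.

The compounds shown do not reveal which part of the entering group accounts for the gain, whether the amino link to the core, the cyclohexyl ring or the amine at the far end of that ring. A plain cyclohexylamino group, a short open chain such as 2-aminoethylamino, or the other stereoisomer of the 4-aminocyclohexyl ring at this position would help to separate these parts, and each would be compared directly with compound 3.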